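Moving the Fluorine on the Benzyl Ring of Compound 2

This account rests on a few compounds, and the source may have more. Where it says the series, first, only, none or still open, it means among the compounds named here.

Three compounds share one core and were tested in a functional assay on L1210 cells (Mus musculus) for cytotoxicity, read by cell counting, with a stated time of 2 days; on this read-out lower numbers stand for stronger inhibition and higher numbers for weaker inhibition. Compound 1, `C=C(Br)C(=O)Nc1ccc(/C=C2\SC(=O)N(Cc3ccc(Cl)cc3)C2=O)cc1`, gives 3400 nM. Compound 2, `Nc1cccc(/C=C2\SC(=O)N(Cc3ccc(F)cc3)C2=O)c1`, gives 142000 nM, the second highest of the three numbers; its nearest neighbour is compound 3, `CC(C)(C)c1ccc(CN2C(=O)S/C(=C\c3cccc(N)c3)C2=O)cc1`, which gives 223000 nM, and its furthest is compound 1, whose number lies well beyond the scatter from that of compound 2.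

Compound 4, `Nc1cccc(/C=C2\SC(=O)N(Cc3cccc(F)c3)C2=O)c1`, is not yet measured. It differs from compound 2 in one place: 3-fluorophenyl in place of 4-fluorophenyl on a saturated chain carbon bound to an amide-type nitrogen in a ring. The two molecules contain the same atoms, joined differently.

Among the measured compounds shown here, only one measured step touches this benzyl ring, the change from fluoro to tert-butyl that gives a 1.6-fold higher number from compound 2 to compound 3 (0.20 log units; within the scatter). For the measured compounds named here, that step swaps the group itself rather than shifting the fluorine along the ring, so no measured step shows directly what moving the fluorine does. Since even a swap to a much larger group stayed within the scatter, a shift of the fluorine is expected to give no step beyond the scatter either, meaning a change of about no change at the digits printed from compound 2 to compound 4 (within the scatter).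

Compound 4 is therefore estimated at 142000 nM in this assay, with a plausible range from 50000 nM to 400000 nM.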

Compound 4, half-maximal inhibitory concentration: 199000 nM
For compound 4 the middle estimate is 1.4-fold (0.15 log units) below the measured one; measured number inside the range.
By their numbers in this assay, from the lowest: compound 1; then compounds 2, 4 and 3 (each within the scatter of the next).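

In this assay, shifting the fluorine gives a 1.4-fold higher number from compound 2 to compound 4 (0.15 log units; within the scatter). Among the compounds shown here, this is the first direct reading of where the fluorine sits on this benzyl ring, whereas the earlier step, a 1.6-fold higher number from compound 2 to compound 3 (0.20 log units; within the scatter), replaced the fluorine with tert-butyl and did not move it. Both a change of placement and a change of group at this position therefore stay within the scatter, so neither separates these compounds in this read-out, and no independent measurement is available to explain why they read alike.

From the compounds shown here alone, the benzyl ring has been explored here only with fluoro and tert-butyl, so it remains open whether 2-fluorophenyl, or a benzyl ring carrying an amine or a carboxylic acid, would give a step beyond the scatter. Going by these compounds, it is also open whether the same benzyl changes would read alike on the core of compound 1, which gives 3400 nM.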